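This account rests on a few compounds, and the source may have more. Where it says the series, first, only, none or still open, it means among the compounds named here.

Measured in a functional assay on HCT-116 cells (Homo sapiens) for antiproliferative activity, read by sulforhodamine B assay, with a stated time of 72 h; on this read-out higher numbers stand for weaker inhibition and lower numbers for stronger inhibition:
- compound 1 `COc1ncc(-c2ccc3ncc(NCc4ccccc4)c(OC)c3c2)cc1NS(=O)(=O)c1ccc(F)cc1F`: 16800 nM
- compound 2 `COc1ncc(-c2ccc3ncc(NC(=O)C4CCCCC4)c(OC)c3c2)cc1NS(=O)(=O)c1ccc(F)cc1F`: 4610 nM
- compound 3 `COc1ncc(-c2ccc3ncc(NCC4CCN(C(C)=O)CC4)c(OC)c3c2)cc1NS(=O)(=O)c1ccc(F)cc1F`: 1930 nM

Compound 3 has the lowest number of the three, so it is the strongest inhibitor here, and its gaps to both others lie beyond the scatter. Compound 4 `COc1ncc(-c2ccc3ncc(NC(C)=O)c(OC)c3c2)cc1NS(=O)(=O)c1ccc(F)cc1F` has not yet been measured. It differs from compound 3 on a single side group (acetyl in place of (1-acetylpiperidin-4-yl)methyl on a nitrogen on an aromatic ring).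

Compound 2 is the closest guide, since it also has a carbonyl group on that nitrogen. Among the compounds with values here, two measured steps bear on the change, and both are modest: a 2.4-fold lower number from compound 2 to compound 3 (0.38 log units; beyond the scatter) and a 3.6-fold lower number from compound 1 to compound 2 (0.56 log units; beyond the scatter). Neither shows what happens with so few atoms on that nitrogen, so the uncertainty is wide. In this assay the expected result is no step beyond the scatter (a 1.3-fold higher number from compound 3 to compound 4 (0.11 log units; within the scatter)), with a slight rise in the number if anything. Compound 4 is therefore estimated at 2500 nM with an expected range reaching from 600 nM to 9000 nM (an estimate, not a measurement).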

Compound 4, half-maximal inhibitory concentration: 550 nM
Compound 4: middle estimate off by 4.5-fold (0.66 log units), on the high side; the measured number lies below the stated range.
By their numbers in this assay, from the lowest: compound 4; then compound 3; then compound 2; then compound 1.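

In this assay, acetyl gives the lowest number of this set, with a 3.5-fold lower number from compound 3 to compound 4 (0.55 log units; beyond the scatter), an 8.4-fold lower number from compound 2 to compound 4 (0.92 log units; beyond the scatter) and a 31-fold lower number from compound 1 to compound 4 (1.48 log units; beyond the scatter). A large group on this nitrogen is therefore not needed for stronger inhibition, and the short acetyl outdoes the three larger groups shown, whether they carry a carbonyl directly on the nitrogen, as in compound 2, or a saturated carbon there, as in compound 1 and compound 3. Nothing given here explains why the number falls with this change.

The compounds shown leave open whether a bare amine on this nitrogen, or a propanoyl group with its slightly longer chain, would give a lower number still. They also leave open how an ethyl group, of similar length but without the carbonyl, would compare with acetyl.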